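Replacing a Small Hydroxy with a Fused Two-Ring Group

This account rests on a few compounds, and the source may have more. Where it says the series, first, only, none or still open, it means among the compounds named here.

Compound 1, `CCCCc1oc2ccc(/N=C/c3ccc(O)cc3)cc2c1C(=O)c1ccc(OC)cc1`: 22.8 ug/mL
Compound 2, `CCCCc1oc2ccc(/N=C/c3ccccc3)cc2c1C(=O)c1ccc(OC)cc1`: 34.2 ug/mL
Compound 3, `CCCCc1oc2ccc(/N=C/c3ccccc3O)cc2c1C(=O)c1ccc(OC)cc1`: 99.4 ug/mL

The three measured compounds share one core and differ only in the ring attached to the carbon of the carbon–nitrogen double bond. In a functional assay, with a stated time of 30 min (a higher number here means a weaker inhibitor, a lower number a stronger inhibitor), compound 3 gives 99.4 ug/mL, the highest of the three numbers; its steps to both other compounds lie beyond the scatter, so it is the weakest inhibitor of the set.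

Compound 4, `CCCCc1oc2ccc(/N=C/c3ccccc3-c3cc4ccccc4cc3O)cc2c1C(=O)c1ccc(OC)cc1`, differs from compound 3 in one place: 3-hydroxynaphthalen-2-yl in place of hydroxy on an aromatic carbon. Among the compounds with values here, no measured step introduces a group of this kind, so the only guidance comes from the steps that concern the hydroxy now being removed: a 2.9-fold higher number from compound 2 to compound 3 (0.46 log units; beyond the scatter) and a 4.4-fold higher number from compound 1 to compound 3 (0.64 log units; beyond the scatter). Both show that a hydroxy in that position raised the number modestly. Taking it away might therefore move compound 4 back toward compound 2, yet the entering group is much larger, and nothing measured tells how such a group behaves there. The expected outcome is a modest downward step, a 2.0-fold lower number from compound 3 to compound 4 (0.30 log units; within the scatter), with wide uncertainty. Compound 4 is estimated at 50 ug/mL, expected to fall between 15 ug/mL and 170 ug/mL.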

Compound 4, half-maximal inhibitory concentration: 39.5 ug/mL
The estimate for compound 4 lay 1.3-fold (0.10 log units) above the measured number; the range from low to high includes it.
By their numbers in this assay, from the lowest: compounds 1, 2 and 4 (each within the scatter of the next); then compound 3.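

In this assay, putting 3-hydroxynaphthalen-2-yl in place of the hydroxy gives a 2.5-fold lower number from compound 3 to compound 4 (0.40 log units; beyond the scatter), so this position, ortho to a large group, tolerates a far larger entering group, with 11 heavy atoms and 2 six-membered aromatic rings, without any rise in the number. Set against hydrogen at the same carbon, the fused two-ring group gives a 1.2-fold higher number from compound 2 to compound 4 (0.06 log units; within the scatter), which means compound 2 and compound 4 cannot be told apart here, and the raised number of compound 3 is not shared by this much larger group. Nothing available gives a reason for either step.

The compounds shown leave open whether the hydroxy carried on the fused rings plays any part in the result, a question that a plain naphthalen-2-yl group at the same carbon would address. Going by these compounds, it also remains open how a smaller ring such as phenyl, or a group of a different kind such as an amine or a carboxylic acid, would behave at this position.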